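The source may hold more compounds than are shown below. What is called first, only, known or untested is meant among the compounds shown, and "the series" means these compounds.

Measured compounds in a functional assay on NCI-H23 cells (Homo sapiens) for antiproliferative activity; a higher number here means a weaker inhibitor of growth, a lower number a stronger inhibitor of growth:
compound 1 `O=C(CCC1=CCN(Cc2ccc(C(F)(F)F)cc2)C1=O)NO` gives 6640 nM
compound 2 `COc1ccc(CN2CC=C(CCC(=O)NO)C2=O)cc1` gives 1640 nM

Among the compounds with values here, compound 2 stands at the lowest of the two numbers so far; its nearest neighbour is compound 1, and the two are separated by the step of a 4.0-fold lower number from compound 1 to compound 2 (0.61 log units; beyond the scatter). Within the data shown here, this is the only measured step, and it concerns an exchange of the group on the aromatic carbon that is changed again below.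

Compound 3 `O=C(CCC1=CCN(Cc2ccccc2)C1=O)NO` differs from compound 2 by hydrogen in place of methoxy on an aromatic carbon. Among the measured compounds shown here, the one measured step bears on this only indirectly: a 4.0-fold lower number from compound 1 to compound 2 (0.61 log units; beyond the scatter) shows that the group at this carbon matters beyond the scatter, but neither measured compound carries hydrogen there, so the direction of the new step cannot be read from the data. Either a step within the scatter or a step of a size comparable to the measured one is plausible, somewhat more likely toward a higher number. For compound 3 the expected value in this assay is 2500 nM, with a range of 900 nM to 7000 nM. The step expected is a 1.5-fold higher number from compound 2 to compound 3 (0.18 log units; within the scatter).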

Compound 3, concentration for 50% growth inhibition: 4290 nM
Compound 3: the middle estimate sits 1.7-fold (0.23 log units) below what was measured, within the range that was stated.
By their numbers in this assay, from the lowest: compound 2; then compounds 3 and 1 (each within the scatter of the next).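

In this assay, hydrogen now gives a reference point on this aromatic carbon, para to a large group, and the comparison separates the two earlier substituents. Removing methoxy gives a 2.6-fold higher number from compound 2 to compound 3 (0.42 log units; beyond the scatter), whereas the exchange of trifluoromethyl for hydrogen gives a 1.5-fold lower number from compound 1 to compound 3 (0.19 log units; within the scatter), so among the three compounds only methoxy stands apart from hydrogen, and trifluoromethyl and hydrogen cannot be told apart here. Compound 2 remains the strongest inhibitor of growth of the three, with its steps to both other compounds beyond the scatter, and no supporting measurement is available to explain this difference.

Going by these compounds, whether the advantage is specific to methoxy or is shared by other groups on this carbon, such as ethoxy, hydroxyl or an amine, remains open. Also open, on these data alone, is how this substituent effect would carry over to analogues with a longer chain or with a carboxylic acid in place of the hydroxamic acid.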